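Shortening the Alkyl Chain from Compound 3 to Compound 4

The compounds below may be only part of what the source reports. "The series", "measured", "known", "first", "only" and "open" are said of these compounds alone.

Of the compounds shown here, three have so far been measured in a functional assay on PC-3 cells (Homo sapiens) for antiproliferative activity, read by MTT assay, with a stated time of 72 h; on this read-out higher numbers stand for weaker inhibition and lower numbers for stronger inhibition. Compound 1, `CCCCCCCCCCNC[C@@H]1OC[C@H](N)[C@@H]1O`, gives 11900 nM. Compound 2, `CCCCCCCNC[C@@H]1OC[C@H](N)[C@@H]1O`, gives 22400 nM, and compound 3, `CCCCCCCCCCCNC[C@@H]1OC[C@H](N)[C@H]1O`, gives 10000 nM. Compound 3 and compound 1 differ in their cores, and the difference between the two cores is not broken down here. Between compound 1 and compound 2 the change is hydrogen in place of propyl on a saturated chain carbon, seven bonds along the chain from an amine nitrogen, and it made a step of a 1.9-fold higher number from compound 1 to compound 2 (0.27 log units; within the scatter). Compound 4, `CCCCCCCCNC[C@@H]1OC[C@H](N)[C@H]1O`, has not yet been measured. It differs from compound 3 by hydrogen in place of propyl on a saturated chain carbon, eight bonds along the chain from an amine nitrogen. This is the same kind of change as that from compound 1 to compound 2, though not the same: in the earlier pair the place is seven bonds along the chain from an amine nitrogen, here it is eight bonds along the chain from an amine nitrogen. The change occurs twice among these compounds. The expected step from compound 3 to compound 4 is a 1.9-fold higher number from compound 3 to compound 4 (0.28 log units; within the scatter), an expectation that rests on the measured step of a 1.9-fold higher number from compound 1 to compound 2 (0.27 log units; within the scatter). Compound 4 is therefore estimated at 19000 nM, with a range from 9000 nM to 40000 nM.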

Compound 4, half-maximal inhibitory concentration: 13000 nM
The estimate for compound 4 lay 1.5-fold (0.16 log units) above the measured number, and the stated range covers the measured number.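

In this assay, hydrogen in place of propyl gave a 1.3-fold higher number from compound 3 to compound 4 (0.11 log units; within the scatter), and set beside the earlier step on the other core, the two agree: the same change on two cores in this assay, a 1.9-fold higher number (0.27 log units; within the scatter) from compound 1 to compound 2 and a 1.3-fold higher number (0.11 log units; within the scatter) from compound 3 to compound 4, 1.4-fold (0.16 log units) apart, within the scatter of two such steps. For these two cores, then, the change carries over with no step size that can be told apart, even though the place is seven bonds along the chain from an amine nitrogen in the earlier pair and eight bonds along the chain from an amine nitrogen in the new one. This does not show that shortening the chain has a real effect on either core, as neither step lies beyond the scatter, and two pairs say nothing about how the change would behave on any further core.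

The compounds shown leave open how a longer chain, or a chain ending in a hydroxyl group or a carboxylic acid, would read in this assay. They also leave open whether an amide in place of the chain amine would give the same steps on both cores.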